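Substituent changes on the saturated ring carbon of the shared core

The source may report more compounds than this note shows. Statements on the series, on what has been measured and on what is new or still open speak of the compounds shown alone.

In a functional assay on HEK293 cells for agonist activity at G-protein coupled receptor 39 (Homo sapiens), read by scintillation proximity assay and inositol phosphate accumulation, with a stated time of 75 min, in the presence of a further agent that is not named here (a higher number here means that more compound is needed for the effect, a lower number that less compound is needed), compound 1 `Cc1cc(C)n(CCOC2CC(=O)Nc3c2c(C)nn3-c2ncnc3nc[nH]c23)n1` gives 16 nM; compound 2 `Cc1noc(C)c1COC1CC(=O)Nc2c1c(C)nn2-c1ncnc2nc[nH]c12` gives 5 nM, and compound 3 `Cc1nn(-c2ncnc3nc[nH]c23)c2c1C(NC(=O)c1ccccc1)CC(=O)N2` gives 3 nM. Compound 3 stands at the lowest number of the three: the step of a 5.3-fold lower number from compound 1 to compound 3 (0.73 log units; beyond the scatter) lies beyond the scatter, while a 1.7-fold lower number from compound 2 to compound 3 (0.22 log units; within the scatter) lies within it. Compound 4 `Cc1nn(-c2ncnc3nc[nH]c23)c2c1C(OCC(C)C)CC(=O)N2` differs from compound 3 at the saturated ring carbon only: isobutoxy in place of benzamido on a saturated ring carbon. Among the measured compounds shown here, the steps that bear on this change are the two on the same carbon, a 3.2-fold lower number from compound 1 to compound 2 (0.51 log units; beyond the scatter) and a 1.7-fold lower number from compound 2 to compound 3 (0.22 log units; within the scatter), so only a small rise in number is expected for compound 4, because the replacements at this carbon seen so far reached at most a 5.3-fold lower number from compound 1 to compound 3 (0.73 log units; beyond the scatter). Compound 4 is therefore estimated at 8 nM, range 3 nM to 25 nM, a step of a 2.7-fold higher number from compound 3 to compound 4 (0.43 log units; beyond the scatter).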

Compound 4, half-maximal effective concentration: 4 nM
Compound 4: middle estimate off by 2.0-fold (0.30 log units), on the high side, within the range that was stated.
By their numbers in this assay, from the lowest: compounds 3, 4 and 2 (each within the scatter of the next); then compound 1.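

In this assay, the saturated ring carbon tolerates isobutoxy, with no ring and no hydrogen-bond donor, as well as benzamido: a 1.3-fold higher number from compound 3 to compound 4 (0.12 log units; within the scatter). On the ether side, isopropyl on the chain carbon matches 3,5-dimethyl-1,2-oxazol-4-yl, a 1.3-fold lower number from compound 2 to compound 4 (0.10 log units; within the scatter), whereas replacing (3,5-dimethyl-1H-pyrazol-1-yl)methyl with isopropyl gives a 4.0-fold lower number from compound 1 to compound 4 (0.60 log units; beyond the scatter), so neither an aromatic ring nor an amide is required here among these compounds. No available evidence bears on these steps.

The compounds shown leave open how a primary amine, a carboxylic acid or a longer alkyl chain at this carbon would read.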